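Methyl for Trichloromethyl on a Sulfonyl Sulfur

The source may report more compounds than this note shows. Statements on the series, on what has been measured and on what is new or still open speak of the compounds shown alone.

Measured compounds:
compound 1 `O=[N+]([O-])c1ccccc1NC1CCCCC1`: in an assay on cells for inhibition of serine/threonine-protein kinase WNK1 (Homo sapiens), read by luminescence and Kinase-Glo, with a stated time of 2 h (on this read-out higher numbers stand for weaker inhibition and lower numbers for stronger inhibition), compound 1 gives > 1000000 nM, a limit of the assay.
compound 2 `O=[N+]([O-])c1cc(S(=O)(=O)C(Cl)(Cl)Cl)ccc1NC1CCCCC1`: in this assay compound 2 gives > 1000000 nM, also a limit.

Both values sit at the limit of > 1000000 nM in this assay, at which 2 of the 2 values shown sit, so the step that the two limits leave unreadable from compound 1 to compound 2 cannot be sized. Compound 3 `CS(=O)(=O)c1ccc(NC2CCCCC2)c([N+](=O)[O-])c1` differs from compound 2 by methyl in place of trichloromethyl on a sulfonyl sulfur. For the measured compounds named here, the only measured step that touches this sulfonyl group is the unreadable one from compound 1 to compound 2, so no step gives a readable size for the change. Compound 2 stands at the limit, and compound 3 is expected to stay there, with an estimated step of a number no higher from compound 2 to compound 3 (the limit leaves the size open). The estimate for compound 3 is 1000000 nM, in the range 300000 nM to 3000000 nM.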

Compound 3, half-maximal inhibitory concentration: > 1000000 nM
Compound 3 ended at the assay's limit; the forecaster's own chance of this, stated with the estimate: 85%; the middle value lies on the limit itself.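

Compound 3 gives a limit, as do compound 1 and compound 2, so none of the steps among these compounds can be read: the limit of > 1000000 nM in this assay, at which 3 of the 3 values shown sit.

The compounds shown leave open what potency any of them has beyond that limit in this assay.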